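The source may report more compounds than this note shows. Statements on the series, on what has been measured and on what is new or still open speak of the compounds shown alone.

Values so far in a functional assay on MDA-MB-361 cells (Homo sapiens) for cytotoxicity, read by sulforhodamine B assay, with a stated time of 2 days (on this read-out higher numbers stand for weaker inhibition and lower numbers for stronger inhibition), are these
- compound 1 `Cc1cc(N(C)C)ccc1-c1nc2c(s1)[C@H](O)CCC2` gives 83 nM
- compound 2 `OC1CCCc2nc(-c3ccc(N4CCCC4)cc3)sc21` gives 200 nM
- compound 3 `CN(C)c1ccc(-c2nc3c(s2)C(O)CCC3)c(CO)c1` gives 420 nM

Compound 1 has the lowest number of the three, and its gaps to both compound 2 and compound 3 lie beyond the scatter. The next compound to be read is compound 4 `Cc1cc(N(C)C)ccc1-c1nc2c(s1)[C@@H](O)CCC2`, which differs from compound 1 only in configuration as drawn (the two compounds have the same atoms and bonds and differ only in configuration as drawn: 1 of 1 stereo elements differ; a stereocentre at a saturated ring carbon is drawn R in compound 1 and S in compound 4): a stereocentre at a saturated ring carbon is drawn R in compound 1 and S in compound 4. Among the compounds with values here, compound 2 and compound 3 are drawn without configuration at their stereocentre, so no measured pair shows what this inversion does. The expected direction is toward weaker inhibition, resting only on the low position of compound 1 at 83 nM in this small set, and the size remains uncertain. The estimated change is a 1.9-fold higher number from compound 1 to compound 4 (0.29 log units; within the scatter) in this assay, and a result within the scatter cannot be excluded. For compound 4 the expected value is 160 nM as the central estimate. The estimated range for compound 4 runs from 50 nM to 700 nM on this read-out.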

Compound 4, half-maximal inhibitory concentration: 160 nM
For compound 4 middle estimate and measured number coincide at the digits printed; the measured number falls inside the stated range.
By their numbers in this assay, from the lowest: compounds 1, 4 and 2 (each within the scatter of the next, the first and the last beyond it); then compound 3.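

Within the data shown here, compound 1 and compound 4 give the first direct reading of configuration at this saturated ring carbon, which the earlier compounds could not give: the fact that compounds 1 and 4 differ only in the configuration as drawn. In this assay the pair shows a 1.9-fold higher number from compound 1 to compound 4 (0.29 log units; within the scatter), so on this read-out the configurations drawn R and S are not separated. Cytotoxicity in this assay therefore does not depend on one drawn configuration at this position, at least with the rest of compound 1 held fixed.

As far as these compounds go, compound 2 and compound 3 are drawn without configuration at their stereocentre, so whether the two forms also stay this close with those other substituents remains open. Also open, from the compounds shown here alone, is what a ketone or a methyl ether would give at this saturated ring carbon in place of the hydroxyl.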